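This account rests on a few compounds, and the source may have more. Where it says the series, first, only, none or still open, it means among the compounds named here.

Measured compounds in a functional assay (cardiac atrium) for agonist activity, with Cavia porcellus as the target; a lower number here means that less compound is needed, a higher number that more compound is needed for the effect:
- compound 1 `CC1=NC(C)=C([N+](=O)[O-])C(c2ccncc2)/C1=C(\O)OC(C)(C)C`: 2820 nM
- compound 2 `CC1=NC(C)=C([N+](=O)[O-])C(c2ccncc2)/C1=C(\O)OC(C)C`: 8050 nM
- compound 3 `CC1=NC(C)=C([N+](=O)[O-])C(c2ccncc2)/C1=C(\O)OC1CCCC1`: 4250 nM

Among these three numbers compound 3 stands second highest. Its nearest neighbour is compound 1, a 1.5-fold higher number from compound 1 to compound 3 (0.18 log units; within the scatter), and its furthest is compound 2, a 1.9-fold lower number from compound 2 to compound 3 (0.28 log units; within the scatter); both of these gaps lie within the scatter, so no order can be read between compound 3 and either of them. Within the data shown here, the one step that goes beyond the scatter is a 2.9-fold higher number from compound 1 to compound 2 (0.46 log units; beyond the scatter), which shows that the group on the oxygen bound to the unsaturated carbon can move the number modestly.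

Compound 4 `COCCO/C(O)=C1\C(C)=NC(C)=C([N+](=O)[O-])C1c1ccncc1` carries a different group at that same place: 2-methoxyethyl in place of cyclopentyl on an oxygen on an unsaturated carbon. Among the measured compounds shown here, none of the measured steps involves 2-methoxyethyl, so no step bears directly on this change; the measured changes at this place ranged from within the scatter to modest. A step of at most modest size in either direction is therefore expected, most likely none beyond the scatter.

For compound 4 the estimate in this assay is 5000 nM, with a range from 2000 nM to 13000 nM, meaning an expected step of a 1.2-fold higher number from compound 3 to compound 4 (0.07 log units; within the scatter).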

Compound 4, half-maximal effective concentration: 37700 nM
Beside the measured number, compound 4's estimate is 7.5-fold (0.88 log units) below it; the measured number lies above the stated range.
By their numbers in this assay, from the lowest: compounds 1, 3 and 2 (each within the scatter of the next, the first and the last beyond it); then compound 4.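

At this place, on an oxygen on an unsaturated carbon, 2-methoxyethyl stands apart from all three carbon-only groups in this assay: cyclopentyl (an 8.9-fold higher number from compound 3 to compound 4 (0.95 log units; beyond the scatter)), isopropyl (a 4.7-fold higher number from compound 2 to compound 4 (0.67 log units; beyond the scatter)) and tert-butyl (a 13-fold higher number from compound 1 to compound 4 (1.13 log units; beyond the scatter)). Among these compounds, the step from tert-butyl is large, so this position can shift the number much further than the earlier compounds showed, and here a group with an oxygen in its chain needs the most compound of the four. Nothing available explains why this change has such an effect.

A plain butyl chain, with carbon where the chain's oxygen stands, would show whether that oxygen goes with the higher number. A 2-hydroxyethyl group or an amine on the same chain remains an open comparison as well.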